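Cyano to fluoro swap on the aromatic carbon

The compounds below may be only part of what the source reports. "The series", "measured", "known", "first", "only" and "open" are said of these compounds alone.

Compound 2 `CSc1ccc(COCC#CC(O)c2ccc(C#N)cc2)cc1` gives 41000 nM in an assay on isolated protein for inhibition of Polyunsaturated fatty acid 5-lipoxygenase (Homo sapiens); a higher number here means a weaker inhibitor, a lower number a stronger inhibitor. Compound 1 `COc1ccc(C(O)C#CCOCc2ccc(SC)cc2)cc1OC` gives 80000 nM in this assay; the gap between these two numbers sits within the scatter, so no order between compound 1 and compound 2 can be read. Compound 3 `OC(C#CCOCc1ccccc1)c1ccccc1` gives > 100000 nM in this assay, which is a limit of the assay rather than a number. This is recorded as the limit of > 100000 nM in this assay, at which 1 of the 3 values shown sits. Compound 2 therefore holds the lower of the two numbers shown, but only by a margin that the scatter covers.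

Compound 4 `CSc1ccc(COCC#CC(O)c2ccc(F)cc2)cc1` has not yet been measured. It differs from compound 2 by fluoro in place of cyano on an aromatic carbon. Going by the values given here, no measured pair separates this particular change, and the only two numbers in hand, from compound 1 and compound 2, carry different groups on that ring yet sit within scatter of one another. The step from compound 2 to compound 4 in this assay is therefore expected to be small, within the scatter or slightly toward a higher number, as a 1.5-fold higher number from compound 2 to compound 4 (0.17 log units; within the scatter). Compound 4 is estimated at 60000 nM, with a range from 25000 nM to 150000 nM. Given where compound 3 sits, a reported limit instead of a number for compound 4 cannot be ruled out.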

Compound 4, half-maximal inhibitory concentration: 12000 nM
Compound 4: middle estimate off by 5.0-fold (0.70 log units), on the high side; the whole stated range lies above it.
By their numbers in this assay, from the lowest: compound 4; then compounds 2 and 1 (each within the scatter of the next). At a limit, above all of these: compound 3.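

The step in this assay gives the series its first pair differing in one place, and a 3.4-fold lower number from compound 2 to compound 4 (0.53 log units; beyond the scatter) shows that the aromatic carbon para to a large group responds to a change of substituent. Going by these compounds alone, the step is modest but lies beyond the scatter, so fluoro in place of cyano at this position has a readable effect on the number, which the earlier compounds could not show, as none of them formed such a pair. Nothing among the data shown accounts for the direction or size of this step, and a single pair sets no trend for the position.

Open at this same aromatic carbon is how other groups would read against fluoro and cyano, for example an amine, a carboxylic acid, a chloro group or a longer chain, and whether any of them would move the number further than this step. Compound 3 stays a limit of the assay and not a number, and no step to it can be read: the limit of > 100000 nM in this assay, at which 1 of the 4 values shown sits.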